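The source may hold more compounds than are shown below. What is called first, only, known or untested is meant among the compounds shown, and "the series" means these compounds.

In a functional assay on HCT-116 cells (Homo sapiens) for cytotoxicity, read by sulforhodamine B assay, with a stated time of 48 h (on this read-out higher numbers stand for weaker inhibition and lower numbers for stronger inhibition), compound 1 `O=C(Nc1n[nH]c2c1CN(C(=O)c1ccccc1)C2)c1ccccc1` gives 6400 nM and compound 2 `O=C(Nc1n[nH]c2c1CN(C(=O)c1ccccc1)C2)c1ccc(F)cc1` gives 3190 nM. Compound 3 `CC(=O)n1nc(NC(=O)c2ccccc2)c2c1CN(C(=O)c1cccc([N+](=O)[O-])c1)C2` has the highest of the three numbers, at 17300 nM. Compound 4 `CC(=O)n1nc(NC(=O)c2ccccc2)c2c1CN(C(=O)c1ccc([N+](=O)[O-])cc1)C2` keeps the same atoms, joined differently: 4-nitrophenyl in place of 3-nitrophenyl on a carbonyl carbon, with 4-nitrophenyl in place of 3-nitrophenyl on a carbonyl carbon. For the measured compounds named here, the only measured single-place step is a 2.0-fold lower number from compound 1 to compound 2 (0.30 log units; within the scatter). Going by the values given here, that step is fluoro in place of hydrogen on an aromatic carbon, a different change, and no measured step covers this exchange. No shift beyond the scatter is therefore expected in this assay. The estimated step is a 1.2-fold lower number from compound 3 to compound 4 (0.06 log units; within the scatter). For compound 4 the expected value is 15000 nM, within a range of 6000 nM to 38000 nM.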

Compound 4, half-maximal inhibitory concentration: 16200 nM
The estimate for compound 4 lay 1.1-fold (0.03 log units) below the measured number; measured number inside the range.
By their numbers in this assay, from the lowest: compounds 2 and 1 (each within the scatter of the next); then compounds 4 and 3 (each within the scatter of the next).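

In this assay, the exchange gives a 1.1-fold lower number from compound 3 to compound 4 (0.03 log units; within the scatter), so at this place, a carbonyl carbon whose other neighbours include an amide-type nitrogen in a ring, 3-nitrophenyl and 4-nitrophenyl are not told apart. For the compounds shown here, this is the first measured step at this place, as the earlier step concerned fluoro in place of hydrogen on an aromatic carbon. Nothing measured here accounts for the result. Going by these compounds, whether an aminophenyl or carboxyphenyl group at this place would shift the number remains open. No pair shown isolates the acetyl group of compounds 3 and 4 either.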